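Uracil alkynes with a free diol: swapping the alkyne cap

The source may report more compounds than this note shows. Statements on the series, on what has been measured and on what is new or still open speak of the compounds shown alone.

Measured compounds:
Compound 1 `CC(=O)OCC(CCn1cc(C#CCCCCl)c(=O)n(C(=O)c2ccccc2)c1=O)COC(C)=O` gives 52800 nM in a functional assay on HeLa cells (Homo sapiens) for antiproliferative activity, read by MTT assay, with a stated time of 72 h; a lower number here means a stronger inhibitor, a higher number a weaker inhibitor.
Compound 2 `O=c1[nH]c(=O)n(CCC(CO)CO)cc1C#Cc1cc(F)cc(F)c1` gives 31200 nM in this assay.

Within the data shown here, only two compounds have been run in this assay. Compound 2 and compound 1 differ at several places at once, and their two numbers sit within the usual scatter of one another, so neither can be called the stronger of the pair; both are weak.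

Compound 3 `O=c1[nH]c(=O)n(CCC(CO)CO)cc1C#CCCCCl` keeps the free diol of compound 2 and changes only the alkyne cap: 3-chloropropyl in place of 3,5-difluorophenyl on a triple-bonded carbon. Among the measured compounds shown here, no step between measured compounds isolates this change. Since compound 1, which carries the same chloropropyl-capped alkyne, gives 52800 nM, and compound 2 gives 31200 nM, little movement is expected. Compound 3 is expected to stay weak, with an estimated 45000 nM (range 15000 nM to 150000 nM), a step of a 1.4-fold higher number from compound 2 to compound 3 (0.16 log units; within the scatter) that is expected to remain within the scatter.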

Compound 3, half-maximal inhibitory concentration: > 100000 nM
Compound 3: no number, only a limit; the forecaster's own chance of this, stated with the estimate: 20%; middle value at least 2.2-fold (0.34 log units) from the limit.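

In this assay compound 3 gives no number, only a limit of the assay: the limit of > 100000 nM in this assay, at which 1 of the 3 values shown sits. Even so, 3-chloropropyl in place of 3,5-difluorophenyl on a triple-bonded carbon can be read as a single change, and it gives an at least 3.2-fold higher number from compound 2 to compound 3 (0.50 log units; beyond the scatter). This shows that, with the free diol held fixed, the cap on the alkyne matters to the antiproliferative read-out, which compound 1 and compound 2 could not show because they differ at several places at once.

Going by these compounds, how far the true value of compound 3 lies past its limit stays open, so the size of this step is known from one side only. The compounds shown also leave open whether the difluoro substitution or the aromatic ring itself carries the difference, and how an unsubstituted phenyl cap or a longer chain ending in an amine would behave.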